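This account rests on a few compounds, and the source may have more. Where it says the series, first, only, none or still open, it means among the compounds named here.

Values in a functional assay on PC-3 cells (Homo sapiens) for antiproliferative activity, read by sulforhodamine B assay; on this read-out lower numbers stand for stronger inhibition of growth and higher numbers for weaker inhibition of growth:
Compound 1 `CC(C)(C)CCOc1cccc(O)c1C(=O)/C=C/c1ccc(O)cc1`: 3220 nM
Compound 2 `O=C(/C=C/c1ccc(O)cc1)c1c(O)cccc1OCCC1CCCCC1`: > 30000 nM (a limit)
Compound 3 `O=C(/C=C/c1ccc(O)cc1)c1c(O)cccc1OCC1CCCCC1`: > 30000 nM (a limit)

Compound 1 is the only one of these with a number, as the other two values are limits. Compound 4 `CC(C)COc1cccc(O)c1C(=O)/C=C/c1ccc(O)cc1` departs from compound 1 in one place (isopropyl in place of neopentyl on a saturated chain carbon bound to an oxygen on an aromatic ring). The two readable steps at this place are an at least 9.3-fold higher number from compound 1 to compound 2 (0.96 log units; beyond the scatter) and an at least 9.3-fold higher number from compound 1 to compound 3 (0.96 log units; beyond the scatter), both beyond the scatter and both bringing in cyclohexyl. The isopropyl of compound 4 has no ring, so these steps guide only weakly. No step beyond the scatter is expected in this assay, and the estimated step is a 1.4-fold higher number from compound 1 to compound 4 (0.15 log units; within the scatter). For compound 4 the expected value is 4500 nM, estimated to lie between 1500 nM and 18000 nM.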

Compound 4, concentration for 50% growth inhibition: 2970 nM
For compound 4 the middle estimate is 1.5-fold (0.18 log units) above the measured one; the range from low to high includes it.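

In this assay, isopropyl and neopentyl at this place read alike, with a 1.1-fold lower number from compound 1 to compound 4 (0.04 log units; within the scatter), so this much trimming of an open-chain group costs nothing measurable. Against the ring-bearing groups, the same place gives an at least 10-fold lower number from compound 3 to compound 4 (1.00 log units; beyond the scatter) and an at least 10-fold lower number from compound 2 to compound 4 (1.00 log units; beyond the scatter), so among the compounds shown, weak inhibition goes only with the cyclohexyl-bearing groups. These two steps are bounded on one side only: the limit of > 30000 nM in this assay, at which 2 of the 4 values shown sit.

As far as these compounds go, whether a phenyl ring or a smaller ring such as cyclopropyl would behave like cyclohexyl remains open. So does the effect of an amine or a carboxylic acid on this chain.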